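A methyl added to the lowest of three compounds

A few compounds are considered here, and "the series" means these few. Any claim that something is new, unique, unknown or untested is made for them only; others in the source may bear on it.

In an ADME assay for permeability, using PAMPA, with a stated time of 4 h (on this read-out lower numbers stand for lower permeability and higher numbers for higher permeability), compound 1 (`Cc1ccc(Oc2ccc3nc(COc4cccc(C(=O)O)c4)n(C)c3n2)cc1`) gives 12.6 10^-6 cm/s and compound 2 (`Cc1ccc(Oc2ccc3nc(COc4cccc(C(=O)O)c4)n(C)c3n2)c(C)c1`) gives 28.8 10^-6 cm/s. Compound 3 (`Cn1c(COc2cccc(C(=O)O)c2)nc2ccc(Oc3ccccn3)cc21`) stands lowest of the three at 2.2 10^-6 cm/s. Compound 4 (`Cc1ccc(Oc2ccc3nc(COc4cccc(C(=O)O)c4)n(C)c3c2)nc1`) differs from it by methyl in place of hydrogen on an aromatic carbon, turning pyridin-2-yl into 5-methylpyridin-2-yl. For the measured compounds named here, only one measured step is of this kind. It is a 2.3-fold higher number from compound 1 to compound 2 (0.36 log units; beyond the scatter), modest and beyond the scatter. It comes from a different pair of compounds, so it is only a guide, but a similar modest rise is expected in this assay. The expected change is a 2.3-fold higher number from compound 3 to compound 4 (0.36 log units; beyond the scatter). For compound 4 the estimate is 5 10^-6 cm/s, with an expected range from 2.2 10^-6 cm/s to 11.5 10^-6 cm/s.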

Compound 4, apparent permeability: 4.8 10^-6 cm/s
For compound 4 the middle estimate is 1.0-fold (0.02 log units) above the measured one; measured number inside the range.
By their numbers in this assay, from the lowest: compound 3; then compound 4; then compound 1; then compound 2.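

In this assay, methyl in place of hydrogen on an aromatic carbon, turning pyridin-2-yl into 5-methylpyridin-2-yl, gives a 2.2-fold higher number from compound 3 to compound 4 (0.34 log units; beyond the scatter). The earlier compounds showed this kind of change only once, whereas it now also appears two atoms from the ring nitrogen, on a different core, with a step of similar size: the same change on two cores in this assay, a 2.3-fold higher number (0.36 log units; beyond the scatter) from compound 1 to compound 2 and a 2.2-fold higher number (0.34 log units; beyond the scatter) from compound 3 to compound 4, 1.0-fold (0.02 log units) apart, within the scatter of two such steps

The compounds shown leave open whether an ethyl chain, a methoxy group or a chlorine atom at this position would shift the number as far. They also cannot tell why methyl raises it.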